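A few compounds are considered here, and "the series" means these few. Any claim that something is new, unique, unknown or untested is made for them only; others in the source may bear on it.

Working notes on the series.

The measured set consists of compound 1 `CCCC(=O)c1ccc(OCCCCOc2cc(C(=O)O)ccc2OC)c(C)c1O`, compound 2 `COc1ccc(C(=O)O)cc1OCCCCOc1ccc(C(C)=O)c(O)c1C` and compound 3 `Cc1c(OCCCCOc2cccc(C(=O)O)c2)ccc(C(=O)CC(C)C)c1O`, all read in an assay on HEK293 cells for positive allosteric modulation of metabotropic glutamate receptor 2 (Rattus norvegicus), read by thallium flux, with a stated time of 2.5 min; a higher number here means that more compound is needed for the effect, a lower number that less compound is needed. Compound 1 gives 103 nM, compound 2 gives 1090 nM, and compound 3 gives 222 nM. Compound 3 thus stands second highest of the three numbers: its nearest neighbour is compound 1, with a lower number beyond the scatter, and its furthest is compound 2, with a higher number beyond the scatter.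

The next compound is compound 4 `COc1ccc(C(=O)O)cc1OCCCCOc1ccc(C(=O)CC(C)C)c(O)c1C`. Relative to compound 3 the change is methoxy in place of hydrogen on an aromatic carbon; the group enters ortho to a large group and para to the carboxy group. Among the compounds with values here, the only step measured so far, an 11-fold higher number from compound 1 to compound 2 (1.02 log units; beyond the scatter), concerns the saturated chain on the carbonyl carbon, not the aromatic ring, so it does not bear on this change. Compound 1 carries the entering methoxy and compound 3 does not, but the two also differ in the acyl chain, so their values alone cannot separate the two effects. Within the data shown here, with no directly comparable step, no movement beyond the scatter is expected, and the estimated step is a 1.1-fold lower number from compound 3 to compound 4 (0.05 log units; within the scatter). For compound 4 in this assay the expected value is 200 nM, within a range of 70 nM to 600 nM.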

Compound 4, half-maximal effective concentration: 155 nM
Estimate against measurement, compound 4: 1.3-fold (0.11 log units) above; measured number inside the range.
By their numbers in this assay, from the lowest: compounds 1, 4 and 3 (each within the scatter of the next, the first and the last beyond it); then compound 2.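

In this assay, within the data shown here, methoxy in place of hydrogen on the aromatic carbon ortho to a large group and para to a carboxy group gives a 1.4-fold lower number from compound 3 to compound 4 (0.16 log units; within the scatter), the first direct reading of this change, and it shows that this place accepts methoxy with no movement beyond the scatter. With the methoxy held constant, the acyl chain can now be read a second and third time: isopropyl in place of hydrogen on the saturated chain carbon bound to the carbonyl carbon gives a 7.0-fold lower number from compound 2 to compound 4 (0.85 log units; beyond the scatter), whereas methyl in place of hydrogen on the saturated chain carbon bound to two saturated chain carbons gives a 1.5-fold higher number from compound 1 to compound 4 (0.18 log units; within the scatter), so in this set the acyl chain moves the number beyond the scatter only in the step involving compound 2. No measurement bearing on the reason for these results is available.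

Going by these compounds, the methoxy reading rests on a single pair, so it remains open whether the same change would stay within the scatter on the shorter acetyl-bearing compounds or on a longer acyl chain. On these data alone, whether ethoxy, a chlorine atom or a hydroxy group would be accepted at this place also remains open.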